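The source may report more compounds than this note shows. Statements on the series, on what has been measured and on what is new or still open speak of the compounds shown alone.

Notes on the series. Among the measured compounds shown here, compound 1 `COc1ccc(Cn2c(CCc3ccccc3)nnc2[C@H](NC(=O)c2ccccn2)c2c[nH]c3ccccc23)cc1` is the reference; in an in vitro assay on LLC-PK1 cells for displacement of a labelled ligand from growth hormone secretagogue receptor type 1 (Homo sapiens) (on this read-out lower numbers stand for stronger inhibition and higher numbers for weaker inhibition), compound 1 gives 0.7 nM, the lowest of the two numbers measured so far. Compound 2 `O=C(N[C@H](c1c[nH]c2ccccc12)c1nnc(CCc2ccccc2)n1-c1ccccc1)c1ccccn1` gives 105 nM in this assay. For the measured compounds named here, the single measured step, a 150-fold higher number from compound 1 to compound 2 (2.18 log units; beyond the scatter), concerns a substituent on an aromatic nitrogen of the shared core and does not touch the carbonyl carbon.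

Compound 3 `COc1ccc(Cn2c(CCc3ccccc3)nnc2[C@H](NC(=O)CCc2cccnc2)c2c[nH]c3ccccc23)cc1` keeps the 4-methoxybenzyl of compound 1 and alters only the acyl group: 2-(pyridin-3-yl)ethyl in place of pyridin-2-yl on a carbonyl carbon. Going by the values given here, no measured pair changes anything on the carbonyl carbon, so the step from compound 1 to compound 2 gives no direct guide to the size or direction of this change; it only shows that the series can move over a wide span in this assay. With 2-(pyridin-3-yl)ethyl in place of pyridin-2-yl on the carbonyl carbon, some loss against compound 1 is expected, estimated as a 5.7-fold higher number from compound 1 to compound 3 (0.76 log units; beyond the scatter), though a result within the scatter cannot be excluded. Compound 3 is therefore expected at 4 nM in this assay, with a range of 0.8 nM to 25 nM.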

Compound 3, half-maximal inhibitory concentration: 177 nM
Beside the measured number, compound 3's estimate is 44-fold (1.65 log units) below it; measured number outside the range, above it.
By their numbers in this assay, from the lowest: compound 1; then compounds 2 and 3 (each within the scatter of the next).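

The acyl group on the carbonyl carbon is a sensitive position in this assay: with the 4-methoxybenzyl held constant, replacing pyridin-2-yl with 2-(pyridin-3-yl)ethyl gives a large loss (a 250-fold higher number from compound 1 to compound 3 (2.40 log units; beyond the scatter)). Both groups carry one six-membered aromatic ring with one hetero atom, the same hydrogen-bond donor and acceptor counts and no net charge, so a change that leaves these counts untouched is still enough to produce a large step. The substituent on the aromatic nitrogen is therefore no longer the only place shown to move this series strongly, but nothing available explains the loss at the carbonyl carbon.

Going by these compounds, this single pair changes the chain and the ring attachment together, so it remains open which of them carries the loss; pyridin-3-yl directly on the carbonyl carbon and 2-(pyridin-2-yl)ethyl would separate the two. Also open, on these data alone, are how a plain phenyl, an amine or a longer chain would read on the carbonyl carbon, and whether the step would keep its size with phenyl in place of 4-methoxybenzyl on the aromatic nitrogen.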